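Furan Replaces Chlorophenyl in a Hydrazone Series

This account rests on a few compounds, and the source may have more. Where it says the series, first, only, none or still open, it means among the compounds named here.

The compounds measured so far in an ADME assay on NIH3T3 cells (Mus musculus) for cytotoxicity, read by MTT assay, with a stated time of 24 h (on this read-out lower numbers stand for stronger inhibition and higher numbers for weaker inhibition), are:
compound 1, `O=C(CSc1nnc(-c2ccncc2)o1)N/N=C/c1ccccc1`, giving 167000 nM;
compound 2, `O=C(CSc1nnc(-c2ccncc2)o1)N/N=C/c1ccc(Cl)cc1`, giving 181000 nM;
compound 3, `O=C(CSc1nnc(-c2ccncc2)o1)N/N=C/c1ccccc1[N+](=O)[O-]`, giving 214000 nM.

Compound 2 stands second highest of the three numbers in this assay; its nearest neighbour is compound 1, and its furthest is compound 3, and both of those gaps are within the scatter. The account now turns to compound 4, `O=C(CSc1nnc(-c2ccncc2)o1)N/N=C/c1ccco1`, which has not yet been measured in this assay. Compared with compound 2 it changes as follows: furan-2-yl in place of 4-chlorophenyl on a carbon with a double bond to nitrogen.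

Among the compounds with values here, two measured steps bear on this change. The step of a 1.1-fold higher number from compound 1 to compound 2 (0.03 log units; within the scatter) adds a chloro group to the aromatic ring, and the step of a 1.2-fold higher number from compound 2 to compound 3 (0.07 log units; within the scatter) exchanges the whole aryl group on the carbon with a double bond to nitrogen; both lie within the scatter, as does a 1.3-fold higher number from compound 1 to compound 3 (0.11 log units; within the scatter). Within the data shown here, nothing measured so far shows that the group on that carbon shifts the number beyond the scatter, so no step beyond the scatter is expected in this assay from compound 2 to compound 4, in either direction.

Compound 4 is therefore expected to give about 185000 nM in this assay, with a range from 100000 nM to 340000 nM. That estimate means an expected step of a 1.0-fold higher number from compound 2 to compound 4 (0.01 log units; within the scatter).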

Compound 4, half-maximal inhibitory concentration: 175000 nM
Compound 4: middle estimate off by 1.1-fold (0.02 log units), on the high side; low and high end bracket the measured number.
By their numbers in this assay, from the lowest: compounds 1, 4, 2 and 3 (each within the scatter of the next).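

In this assay, within the data shown here, the earlier compounds varied only the phenyl ring on the carbon with a double bond to nitrogen, whereas compound 4 replaces that six-membered aromatic ring of carbon only with furan-2-yl, a five-membered aromatic ring with 1 hetero atom. Against the 4-chlorophenyl group the result is a 1.0-fold lower number from compound 2 to compound 4 (0.01 log units; within the scatter) and against the 2-nitrophenyl group it is a 1.2-fold lower number from compound 3 to compound 4 (0.09 log units; within the scatter) while against the unsubstituted phenyl group it is a 1.0-fold higher number from compound 1 to compound 4 (0.02 log units; within the scatter) so all three comparisons remain within the scatter. At this position, then, the four compounds tolerate a change of the ring itself, and not only of a group on it, with no separation in this cytotoxicity read-out.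

As far as these compounds go, all four compounds still carry an aromatic ring on that carbon and share the same core, so it remains open whether an amine, a carboxylic acid or a longer alkyl chain there would move the number beyond the scatter. No supporting evidence is available to explain why these four compounds cannot be told apart in this assay.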